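A few compounds are considered here, and "the series" means these few. Any claim that something is new, unique, unknown or untested is made for them only; others in the source may bear on it.

Working notes on the series. Three compounds share one core and differ only in the aryl group on a saturated ring carbon. Compound 1 `COc1ccc(C2C(C#N)=C(N)N(c3cc(OC)c(OC)c(OC)c3)C3=C2C(=O)CC(C)(C)C3)cc1` carries a 4-methoxyphenyl there; in a functional assay on Ehrlich cells (Mus musculus) for cytotoxicity, tested at 10 ug/mL (a higher number here means a stronger effect of the compound at the concentration tested, a lower number a weaker effect), compound 1 gives 0%. Compound 2 `COc1cc(N2C(N)=C(C#N)C(c3ccccc3O)C3=C2CC(C)(C)CC3=O)cc(OC)c1OC` carries a 2-hydroxyphenyl, and in this assay compound 2 gives 0%. Compound 3 `COc1cc(N2C(N)=C(C#N)C(c3ccc(Cl)cc3Cl)C3=C2CC(C)(C)CC3=O)cc(OC)c1OC` carries a 2,4-dichlorophenyl, and in this assay compound 3 gives 20%. Compound 3 stands highest of the three, since a number 20 percentage points higher from compound 1 to compound 3 (beyond the scatter) and a number 20 percentage points higher from compound 2 to compound 3 (beyond the scatter), whereas no change at the digits printed from compound 1 to compound 2 (within the scatter).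

Compound 4 `COc1cc(N2C(N)=C(C#N)C(c3ccc(C)cc3)C3=C2CC(C)(C)CC3=O)cc(OC)c1OC` is not yet measured. Its change from compound 3: 4-methylphenyl in place of 2,4-dichlorophenyl on a saturated ring carbon

The three measured steps all concern swapping the aryl group on this same carbon. Two aryl groups without chlorine both sit at the bottom of the range, and only the 2,4-dichlorophenyl of compound 3 lifts the number, by a modest amount. A 4-methylphenyl is a third aryl group without chlorine, so the step is expected to go back down, with a number 15 percentage points lower from compound 3 to compound 4 (beyond the scatter) as the expected size, most of the way to the level of compound 1 and compound 2.

Compound 4 is therefore estimated at 5% in this assay, within 0% to 20%.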

Compound 4, a percentage reported as activity, at one concentration (the size of the read-out at that concentration, not a potency): 30%
Estimate against measurement, compound 4: 25 percentage points below; measured number above the stated range.
By their numbers in this assay, from the lowest: compounds 1 and 2 (each within the scatter of the next); then compounds 3 and 4 (each within the scatter of the next).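

In this assay, chlorine on the aryl group proves unnecessary at this saturated ring carbon: a number 10 percentage points higher from compound 3 to compound 4 (within the scatter), so the 4-methylphenyl and the 2,4-dichlorophenyl cannot be told apart here. The aryl groups without chlorine also no longer read alike, with a number 30 percentage points higher from compound 2 to compound 4 (beyond the scatter) and a number 30 percentage points higher from compound 1 to compound 4 (beyond the scatter); the latter step is only methyl in place of methoxy on an aromatic carbon, and compound 4 therefore goes against the earlier split between aryl groups with and without chlorine. No measurement available here explains this difference between the methyl and methoxy compounds.

The compounds shown leave open how this assay would read with a longer alkyl chain in place of the methyl of compound 4, or with a dimethylamino group or a carboxylic acid on this aryl ring. From the compounds shown here alone, the 3,4,5-trimethoxyphenyl group stays the same throughout, so it also remains open whether these steps at the saturated ring carbon would hold with another group in its place.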